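Swapping the sulfonamide substituent in a prostaglandin receptor antagonist series

A few compounds are considered here, and "the series" means these few. Any claim that something is new, unique, unknown or untested is made for them only; others in the source may bear on it.

Measured compounds:
compound 1, `CCCS(=O)(=O)c1cccc(C#Cc2cc(Cl)ccc2OCC(=O)O)c1`: 750 nM
compound 2, `COCCN(C)S(=O)(=O)c1ccc(C)c(C#Cc2cc(Cl)ccc2OCC(=O)O)c1`: 77 nM
compound 3, `CC(C)S(=O)(=O)c1ccc(Cl)c(C#Cc2cc(Cl)ccc2OCC(=O)O)c1`: 67 nM

All three compounds share one core and were tested in a functional assay on cells for antagonist activity at prostaglandin D2 receptor 2 (Homo sapiens), read by flow cytometry, with a stated time of 10 min; on this read-out higher numbers stand for weaker inhibition and lower numbers for stronger inhibition. Compound 2 gives the second highest of the three numbers; its value and that of compound 3 lie within the scatter of each other, while compound 1 sits beyond the scatter with a clearly higher number. Compound 4, `Cc1ccc(S(=O)(=O)N(C)C(C)C)cc1C#Cc1cc(Cl)ccc1OCC(=O)O`, has not yet been measured. It differs from compound 2 by a single change: isopropyl in place of 2-methoxyethyl on a sulfonamide nitrogen. Among the compounds with values here, no measured pair shows this change, so no step size is known from data. The expectation is that the step from compound 2 to compound 4 stays within the scatter, estimated as a 1.1-fold lower number from compound 2 to compound 4 (0.04 log units; within the scatter). Compound 4 is therefore estimated at 70 nM, in the range 30 nM to 160 nM.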

Compound 4, half-maximal inhibitory concentration: 140 nM
Estimate against measurement, compound 4: 2.0-fold (0.30 log units) below, within the range that was stated.
By their numbers in this assay, from the lowest: compounds 3, 2 and 4 (each within the scatter of the next, the first and the last beyond it); then compound 1.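

In this assay, isopropyl in place of 2-methoxyethyl on the sulfonamide nitrogen gives a 1.8-fold higher number from compound 2 to compound 4 (0.26 log units; within the scatter). This first pair at this position shows that a group with one hydrogen-bond acceptor can give way to one with none, with a step that stays within the scatter. No measurement here bears on why the step has this size.

A single pair cannot show how far this tolerance reaches. A longer chain, a terminal amine or a carboxylic acid on this nitrogen remains an open case.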